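Swapping the amino side chain on a shared core

The compounds below may be only part of what the source reports. "The series", "measured", "known", "first", "only" and "open" are said of these compounds alone.

Measured so far:
compound 1 `CCOCC(COCC)Nc1nc(C)nc2c(-c3ccc(OC)cc3C)c(C)nn12` — 19.3 nM
compound 2 `CCN(CC)c1nc(C)nc2c(-c3c(C)cc(OC)cc3OC)c(C)nn12` — 1.2 nM
compound 3 `CCC(CC)Nc1nc(C)nc2c(-c3cc(F)c(OC)cc3C)c(C)nn12` — 1.9 nM

All three were tested in an assay on cell membranes for displacement of a labelled ligand from corticotropin-releasing factor receptor 1 (Rattus norvegicus); a lower number here means a stronger inhibitor, a higher number a weaker inhibitor. Compound 1 stands at the highest of the three numbers in this assay. Its nearest neighbour is compound 3, which gives 1.9 nM, a gap beyond the scatter of repeated measurements. The furthest is compound 2, which gives 1.2 nM, again a gap beyond the scatter. Both neighbours, however, differ from compound 1 in more than one place, so no single change can be read off from them.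

Compound 4 `CCCN(CCC#N)c1nc(C)nc2c(-c3ccc(OC)cc3C)c(C)nn12` keeps the core and the aryl ring of compound 1 and alters only the amino side chain: (2-cyanoethyl)(propyl)amino in place of (2-ethoxy-1-(ethoxymethyl)ethyl)amino on an aromatic carbon. The branched ether-bearing amine gives way to a tertiary amine carrying a propyl chain and a nitrile.

For the measured compounds named here, no measured pair shows exactly this change, so the direction must be an expectation. Given that compound 2, which also carries a tertiary amino group, gives 1.2 nM, a move to a lower number seems likely for compound 4, and the step of a 3.9-fold lower number from compound 1 to compound 4 (0.59 log units; beyond the scatter) is expected to lie beyond the scatter. Compound 4 is therefore estimated at about 5 nM, within a range from 1.5 nM to 20 nM.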

Compound 4, half-maximal inhibitory concentration: 2.16 nM
For compound 4 the middle estimate is 2.3-fold (0.36 log units) above the measured one, within the range that was stated.
By their numbers in this assay, from the lowest: compounds 2, 3 and 4 (each within the scatter of the next); then compound 1.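

For the compounds shown here, with the shared core and the aryl ring held fixed, compound 1 and compound 4 form the first pair in which only the amino side chain changes, and in this assay the result is an 8.9-fold lower number from compound 1 to compound 4 (0.95 log units; beyond the scatter). This shows that the group on this aromatic carbon, between two ring nitrogen atoms, can move the number beyond the scatter on its own, and that a tertiary amine without a hydrogen-bond donor is accepted here, at least on this core with this aryl ring. The swap changes several things at once, removing the ether oxygens and the amine hydrogen and bringing in a nitrile, and nothing available here says which of these differences accounts for the step.

On these data alone, it remains open which part of the new side chain goes with the lower number; a dipropylamino group in this place, which keeps the tertiary amine and drops the nitrile, would speak to that. Also open, as far as these compounds go, is how a ring amine such as morpholine would behave at this position.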